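Chloro to methyl on the aryl ring of compound 1

A few compounds are considered here, and "the series" means these few. Any claim that something is new, unique, unknown or untested is made for them only; others in the source may bear on it.

Compound 1 `Clc1cccc(-c2nnc(C(NCc3ccccc3)c3ccc[nH]3)o2)c1` gives 62200 nM in a functional assay on A549 cells (Homo sapiens) for cytotoxicity, read by MTT assay, with a stated time of 24 h (on this read-out lower numbers stand for stronger inhibition and higher numbers for weaker inhibition), the lower of the two numbers shown, with the other within scatter. Compound 2 `Clc1ccc(-c2nnc(C(NCc3ccccc3)c3ccc[nH]3)o2)cc1` gives 73800 nM in this assay; the step of a 1.2-fold higher number from compound 1 to compound 2 (0.07 log units; within the scatter) is the only one measured, and it concerns where the chloro sits rather than what replaces it. Compound 3 `Cc1cccc(-c2nnc(C(NCc3ccccc3)c3ccc[nH]3)o2)c1` differs from compound 1 as follows: methyl in place of chloro on an aromatic carbon. Within the data shown here, no measured step covers this exchange, and the single known step stays within the scatter, so no step beyond the scatter is expected in this assay. Compound 3 is estimated at 70000 nM, in the range 30000 nM to 160000 nM, with the step of a 1.1-fold higher number from compound 1 to compound 3 (0.05 log units; within the scatter) expected to lie within scatter.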

Compound 3, half-maximal inhibitory concentration: 431000 nM
Beside the measured number, compound 3's estimate is 6.2-fold (0.79 log units) below it; measured number above the stated range.
By their numbers in this assay, from the lowest: compounds 1 and 2 (each within the scatter of the next); then compound 3.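

Methyl in place of chloro gives a 6.9-fold higher number from compound 1 to compound 3 (0.84 log units; beyond the scatter) in this assay, so the identity of the group on this aromatic carbon affects the number, which the chloro-only pair did not show. The step of a 5.8-fold higher number from compound 2 to compound 3 (0.77 log units; beyond the scatter) is read with care, as it changes both group and place. Nothing available explains the difference between chloro and methyl here.

Still open, as far as these compounds go, is whether methoxy, fluoro or an amine on the same aromatic carbon would stay near the chloro compounds or near compound 3. Also open, from the compounds shown here alone, is whether any group there gives a lower number than chloro.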